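Swapping Chloro for Bromo on the Cyclopropyl Amide

This account rests on a few compounds, and the source may have more. Where it says the series, first, only, none or still open, it means among the compounds named here.

In a functional assay on the whole organism with Mus musculus as the target, at a dose of 100 mg/kg by the intraperitoneal route (on this read-out higher numbers stand for more inhibition at the one dose given (going by the name of the read-out) and lower numbers for less inhibition), compound 3 `O=C(/C=C1\CCc2ccc(Cl)cc21)NC1CC1` gives 50%, the second highest of the three numbers shown. Compound 2 `NC(=O)/C=C1\CCc2ccc(Br)cc21` gives 100%, and compound 1 `CNC(=O)/C=C1\CCc2ccc(Br)cc21` gives 0%. For the measured compounds named here, the single step measured between two compounds, a number 100 percentage points higher from compound 1 to compound 2 (beyond the scatter), concerns the amide nitrogen and not the aromatic halogen, so it does not bear on the change leading to compound 4 `O=C(/C=C1\CCc2ccc(Br)cc21)NC1CC1`. That change is bromo in place of chloro on an aromatic carbon. Going by the values given here, no measured pair differs only in this halogen, so nothing in the data points to a step beyond the scatter in this assay. The step is expected to be a number 5 percentage points higher from compound 3 to compound 4 (within the scatter). Compound 4 is estimated at 55%, in a range from 20% to 90%.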

Compound 4, a percentage reported as inhibition, in the whole organism at one dose (the size of the read-out at that dose, not a potency): 33%
Compound 4: middle estimate off by 22 percentage points, on the high side; measured number inside the range.
By their numbers in this assay, from the lowest: compound 1; then compound 4; then compound 3; then compound 2.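

In this assay, for the compounds shown here, the halogen on this aromatic carbon turns out to matter: bromo in place of chloro gives a number 17 percentage points lower from compound 3 to compound 4 (beyond the scatter), a step the earlier compounds could not show. With bromo held fixed, changing the group on the amide nitrogen gives a number 67 percentage points lower from compound 2 to compound 4 (beyond the scatter) and a number 33 percentage points higher from compound 1 to compound 4 (beyond the scatter), so cyclopropyl ranks below hydrogen and above methyl there. Nothing available explains the size of these steps.

From the compounds shown here alone, whether the same halogen swap behaves alike on the plain amide of compound 2 stays open. So does what fluoro or a methoxy group would give on this aromatic carbon.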